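The source may report more compounds than this note shows. Statements on the series, on what has been measured and on what is new or still open speak of the compounds shown alone.

Measured compounds:

Compound 1, `COc1cc(C)cc2c1C(=O)C=C(c1c(C)cc3c(c1OC)C(=O)C(NCCO)=CC3=O)C2=O`: 1410 nM
Compound 2, `CCOc1cc(C)cc2c(O)c(-c3c(C)cc4c(O)ccc(O)c4c3OCC)cc(O)c12`: 1670 nM

Of the compounds shown here, two have so far been measured in a functional assay on HEp-2 cells (Homo sapiens) for cytotoxicity, read by MTT assay, with a stated time of 24 h; on this read-out lower numbers stand for stronger inhibition and higher numbers for weaker inhibition. Compound 1 gives 1410 nM in this assay, and compound 2 gives 1670 nM. These two numbers lie within the usual scatter of each other, so compound 1 cannot be placed ahead of or behind compound 2 on the strength of what has been measured; the pair simply marks the region in which this chemical series has been found to act on these cells.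

Compound 3, `COc1cc(C)cc2c1C(=O)C=C(c1c(C)cc3c(c1OC)C(=O)C(SCCO)=CC3=O)C2=O`, has not yet been measured in this assay. It is derived from compound 1 by a single change: (2-hydroxyethyl)sulfanyl in place of (2-hydroxyethyl)amino on a double-bonded ring carbon. For the measured compounds named here, the shared core of compound 1 is otherwise kept intact, and no measured pair in the set shows what such an exchange of a nitrogen-linked side chain for a sulfur-linked one does to the number in this assay.

With nothing measured to guide the direction, the step from compound 1 to compound 3 is expected to stay within the scatter, a 1.1-fold higher number from compound 1 to compound 3 (0.05 log units; within the scatter). Compound 3 is therefore estimated at 1600 nM in this assay, with a range from 600 nM to 4500 nM.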

Compound 3, half-maximal inhibitory concentration: 1730 nM
Compound 3: middle estimate off by 1.1-fold (0.03 log units), on the low side; the range from low to high includes it.
By their numbers in this assay, from the lowest: compounds 1, 2 and 3 (each within the scatter of the next).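

For the compounds shown here, replacing (2-hydroxyethyl)amino with (2-hydroxyethyl)sulfanyl on a double-bonded ring carbon gives the first measured step for this position in this assay, with a 1.2-fold higher number from compound 1 to compound 3 (0.09 log units; within the scatter) as the result. The earlier compounds shown here could not show this, as compound 1 and compound 2 differ in more than one place; this pair shows that, with the shared core kept intact, a nitrogen-linked side chain and a sulfur-linked one of the same name-length cannot be told apart at this place in these cells. No independent measurement is available to account for this close agreement.

What this single exchange leaves open is whether the position tolerates change in general or only this one, since a longer chain such as 3-hydroxypropylamino, a chain ending in a carboxylic acid or a dimethylamino group might give a quite different number. Going by these compounds, it is also open whether the terminal hydroxyl of the side chain matters, which an unsubstituted ethylamino or ethylsulfanyl group at the same ring carbon would address.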